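This account rests on a few compounds, and the source may have more. Where it says the series, first, only, none or still open, it means among the compounds named here.

In a functional assay on HepG2 cells (Homo sapiens) for cytotoxicity, read by MTT assay, with a stated time of 48 h (a lower number here means a stronger inhibitor, a higher number a weaker inhibitor), compound 1 `O=S(=O)(CCC(F)(Cl)C(F)(F)Cl)c1nc2ccccc2s1` gives 4500 nM, and compound 3 `O=S(=O)(CCC(F)(Cl)C(F)(F)Cl)c1nc2ccc(Cl)cc2s1` gives 6100 nM. The change from compound 3 to compound 1, (hydrogen in place of chloro on an aromatic carbon), produced a 1.4-fold lower number from compound 3 to compound 1 (0.13 log units; within the scatter). Compound 2 `FC(F)(Cl)C(F)(Cl)CCSc1nc2ccc(Cl)cc2s1` is known only as a limit of this assay, > 120000 nM, the limit described as the limit of > 120000 nM in this assay, at which 1 of the 3 values shown sits. The difference between the core of compound 2 and the core of compound 3 is not broken down here. Compound 4 `FC(F)(Cl)C(F)(Cl)CCSc1nc2ccccc2s1` has not yet been measured in this assay; it differs from compound 2 by hydrogen in place of chloro on an aromatic carbon, the same change as that from compound 3 to compound 1 at the same place. Because that earlier step was a 1.4-fold lower number from compound 3 to compound 1 (0.13 log units; within the scatter), a similarly small step is expected here, a step that the limit leaves unreadable from compound 2 to compound 4, most likely leaving compound 4 at the limit as well. Compound 4 is therefore estimated at 150000 nM, with a range from 60000 nM to 400000 nM.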

Compound 4, half-maximal inhibitory concentration: > 120000 nM
Compound 4 ended at the assay's limit (the forecaster's own chance of this, stated with the estimate: 75%); the middle value does not contradict the limit.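

Among these compounds, no step from compound 2 to compound 4 can be read, since both stand at a limit of this assay rather than at a number: the limit of > 120000 nM in this assay, at which 2 of the 4 values shown sit. The compounds shown leave open whether hydrogen in place of chloro on an aromatic carbon changes the cytotoxicity of compound 2 at all.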